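Notes on replacing 4-methylphenyl in compound 3

A few compounds are considered here, and "the series" means these few. Any claim that something is new, unique, unknown or untested is made for them only; others in the source may bear on it.

Values in a functional assay on MCF7 cells (Homo sapiens) for inhibition, read by CCK-8 assay, with a stated time of 48 h; on this read-out lower numbers stand for stronger inhibition and higher numbers for weaker inhibition:
- compound 1 `COc1cc(-c2ccnc3cc(-c4ccc(F)cc4)nn23)cc(OC)c1OC`: 1280 nM
- compound 2 `COc1cc(-c2ccnc3cc(-c4cn(CO)c5ccccc45)nn23)cc(OC)c1OC`: 19 nM
- compound 3 `COc1cc(-c2ccnc3cc(-c4ccc(C)cc4)nn23)cc(OC)c1OC`: 47 nM

For the measured compounds named here, of the three numbers, the one for compound 3 is the middle one: compound 3 gives 47 nM, compared with compound 2 at 19 nM and compound 1 at 1280 nM.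

Compound 4 `COc1cc(-c2ccnc3cc(-c4ccc5c(ccn5C)c4)nn23)cc(OC)c1OC` has 1-methyl-1H-indol-5-yl in place of 4-methylphenyl on an aromatic carbon.

Going by the values given here, the only measured step, a 27-fold lower number from compound 1 to compound 3 (1.44 log units; beyond the scatter), is large and changes the group at this same place, so this assay can respond strongly to changes there. That step swaps only fluoro for methyl, however, and does not predict the effect of this larger replacement. Compound 2, whose group at this place also has a five-membered aromatic ring with a hetero atom and a six-membered aromatic ring of carbon only, gives 19 nM. This suggests that such a group can be accommodated without a loss in the number.

The expected step is a 1.6-fold lower number from compound 3 to compound 4 (0.19 log units; within the scatter), so no change beyond the scatter is expected. For compound 4 the estimated value is 30 nM, with an expected range of 8 nM to 150 nM.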

Compound 4, half-maximal inhibitory concentration: 3 nM
Beside the measured number, compound 4's estimate is 10-fold (1.00 log units) above it, and the stated range ends above it.
By their numbers in this assay, from the lowest: compound 4; then compound 2; then compound 3; then compound 1.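

The larger 1-methyl-1H-indol-5-yl in place of 4-methylphenyl does more than keep activity in this assay: it gives (a 16-fold lower number from compound 3 to compound 4 (1.19 log units; beyond the scatter)), so this position can take a group with a second ring and still gain strongly. Replacing 4-fluorophenyl with the same group gives (a 430-fold lower number from compound 1 to compound 4 (2.63 log units; beyond the scatter)), and compound 4 now has the lowest number of the four compounds shown. No evidence is available to explain why this group lowers the number.

Still open, going by these compounds, is whether the methyl of 1-methyl-1H-indol-5-yl contributes, which a comparison with plain 1H-indol-5-yl would address. Also open, on these data alone, is whether an aminomethyl or a carboxylic acid on the phenyl ring, or a pyridine ring in place of it, would keep the number this low.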